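This account rests on a few compounds, and the source may have more. Where it says the series, first, only, none or still open, it means among the compounds named here.

Working notes on the series. Compound 1 `COc1ccc2ncc(S(=O)(=O)c3ccc(Cl)cc3)c(N3CCC(C)CC3)c2c1` gives 91% in an assay on isolated protein for displacement of a labelled ligand from metabotropic glutamate receptor 5 (Homo sapiens), with a stated time of 60 min, tested at 1 uM; a lower number here means less inhibition, a higher number more inhibition at the concentration tested (going by the name of the read-out). Among the measured compounds shown here, compound 2 `COc1ccc2ncc(S(=O)(=O)c3cccc(F)c3)c(N3CCC(C)CC3)c2c1` gives 68% in this assay, and the step of a number 23 percentage points lower from compound 1 to compound 2 (beyond the scatter) is the only single-point change measured so far; it concerns the group on the sulfonyl sulfur. Compound 3 `CC1CCN(c2c(S(=O)(=O)c3ccc(F)cc3)cnc3ccc(Cl)cc23)CC1` gives 89% in this assay; its number sits close to that of compound 1, with the gap within the scatter, and well above that of compound 2, with the gap beyond the scatter. Compound 3 and compound 1 differ in two places at once, so their values alone say only that both are high.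

Compound 4 `COc1ccc2ncc(S(=O)(=O)c3ccc(F)cc3)c(N3CCC(C)CC3)c2c1` has not been measured. It differs from compound 3 by methoxy in place of chloro on an aromatic carbon. For the measured compounds named here, no measured step touches this position, so the only guide is that compound 1 and compound 2, which both carry methoxy there, span a wide range set by the sulfonyl aryl group, while compound 3 with chloro there is as high as compound 1. A step of small size, within the scatter, is therefore expected in this assay, a number 4 percentage points lower from compound 3 to compound 4 (within the scatter), with no direction favoured. Compound 4 is estimated at 85%, within 68% to 97%.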

Compound 4, a percentage reported as inhibition, at one concentration (the size of the read-out at that concentration, not a potency): 27%
Estimate against measurement, compound 4: 58 percentage points above; the whole stated range lies above it.
By their numbers in this assay, from the lowest: compound 4; then compound 2; then compounds 3 and 1 (each within the scatter of the next).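

In this assay, among the compounds shown here, methoxy in place of chloro on an aromatic carbon of the shared core gives a number 62 percentage points lower from compound 3 to compound 4 (beyond the scatter), so this position, which no earlier step touched, can decide the read-out in a compound carrying the 4-fluorophenyl group on the sulfonyl sulfur. With methoxy held at that position, the sulfonyl aryl group proves sensitive both to the halogen and to where it sits: fluoro in place of chloro gives a number 64 percentage points lower from compound 1 to compound 4 (beyond the scatter), and 4-fluorophenyl in place of 3-fluorophenyl gives a number 41 percentage points lower from compound 2 to compound 4 (beyond the scatter), so a high number with methoxy on the core is possible but depends on that aryl group. Nothing available explains why either change has such a large effect.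

For the compounds shown here, compound 3 is the only compound here with chloro at this position, so whether methoxy in place of chloro gives a step of similar size with 4-chlorophenyl or 3-fluorophenyl on the sulfonyl sulfur remains open. Also open, as far as these compounds go, is how a nitrile, a methyl or an ethoxy group at the same aromatic carbon would read in this assay, and whether the read-out there follows the size of the group or its identity.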